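Bromo substitution on a longer-chain purine analogue

A few compounds are considered here, and "the series" means these few. Any claim that something is new, unique, unknown or untested is made for them only; others in the source may bear on it.

Compound 1 `CCCCCCCC(CCO)n1cnc2c(Cl)ncnc21` is the starting point. In a functional assay on HCT-116 cells (Homo sapiens) for antiproliferative activity, read by MTT assay, with a stated time of 48 h (on this read-out higher numbers stand for weaker inhibition and lower numbers for stronger inhibition), compound 1 gives 4160 nM. Compound 2 `CCCCCCCC(CCO)n1c(Br)nc2c(Cl)ncnc21` carries bromo in place of hydrogen on an aromatic carbon on the core of compound 1; in this assay compound 2 gives 16200 nM, and the step is a 3.9-fold higher number from compound 1 to compound 2 (0.59 log units; beyond the scatter). Compound 3 `CCCCCCCCCC(CCO)n1cnc2c(Cl)ncnc21` differs from compound 1 by ethyl in place of hydrogen on a saturated chain carbon, eight bonds along the chain from an aromatic nitrogen; in this assay compound 3 gives 890 nM, the step being a 4.7-fold lower number from compound 1 to compound 3 (0.67 log units; beyond the scatter), which leaves compound 3 with the lowest number of the three measured.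

Compound 4 `CCCCCCCCCC(CCO)n1c(Br)nc2c(Cl)ncnc21` is not yet measured. It bears the same change on compound 3 that compound 2 bears on compound 1, namely (bromo in place of hydrogen on an aromatic carbon), and the surroundings of the place are described identically in both cases. For the measured compounds named here, the only measured example of this change is the step from compound 1 to compound 2 of a 3.9-fold higher number from compound 1 to compound 2 (0.59 log units; beyond the scatter). On that single precedent the step from compound 3 to compound 4 in this assay is expected to be a 3.9-fold higher number from compound 3 to compound 4 (0.59 log units; beyond the scatter). Compound 4 is therefore estimated at 3500 nM, between 1200 nM and 10000 nM.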

Compound 4, half-maximal inhibitory concentration: 26900 nM
Beside the measured number, compound 4's estimate is 7.7-fold (0.89 log units) below it, outside the stated range (above it).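

In this assay, bromo in place of hydrogen on the aromatic carbon between two ring nitrogen atoms again gives a higher number, here a 30-fold higher number from compound 3 to compound 4 (1.48 log units; beyond the scatter), so the direction of the change carries from the core of compound 1 to the core of compound 3 but its size does not: the same change on two cores in this assay, a 3.9-fold higher number (0.59 log units; beyond the scatter) from compound 1 to compound 2 and a 30-fold higher number (1.48 log units; beyond the scatter) from compound 3 to compound 4, 7.8-fold (0.89 log units) apart, beyond the scatter of two such steps

With bromo in place, the ethyl change gives only a 1.7-fold higher number from compound 2 to compound 4 (0.22 log units; within the scatter), so the gain seen without bromo does not carry over: the same change on two cores in this assay, a 4.7-fold lower number (0.67 log units; beyond the scatter) from compound 1 to compound 3 and a 1.7-fold higher number (0.22 log units; within the scatter) from compound 2 to compound 4, 7.8-fold (0.89 log units) apart, beyond the scatter of two such steps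

These four compounds show that, in this assay, the effect of each change depends on the other, but they do not show why, or whether this would hold for other chains or other read-outs.

The compounds shown leave open whether an amine or a methyl on that aromatic carbon would follow bromo. They also leave open whether a still longer chain would widen the gap between the bromo steps.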